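The source may report more compounds than this note shows. Statements on the series, on what has been measured and on what is new or still open speak of the compounds shown alone.

Working notes on the azetidine series.

Three members of the series have numbers in an assay on HEK293 cells for negative allosteric modulation of metabotropic glutamate receptor 5 (Homo sapiens), read by FLIPR; a lower number here means a stronger inhibitor, a higher number a weaker inhibitor. Compound 1 `Cc1cccc(-c2noc(C3CN(C(=O)C4CCC(C(F)(F)F)CC4)C3)n2)c1` gives only a limit, > 10000 nM, in this assay. Compound 2 `O=C(N1CCC(F)CC1)N1CC(c2nc(-c3cccc(Cl)c3)no2)C1` likewise gives only a limit, > 10000 nM, in this assay. For the measured compounds named here, compound 3 `Cc1ccc(S(=O)(=O)N2CC(c3nc(-c4cccc(Cl)c4)no3)C2)cc1` gives a measured value of 920 nM in this assay, so compound 3 is the one member whose result is a number rather than a limit. Compound 2 thus sits at the limit of > 10000 nM in this assay, at which 2 of the 3 values shown sit, together with compound 1, and nothing more than that limit is known of it.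

Compound 4 `O=C(C1CCC1)N1CC(c2nc(-c3cccc(Cl)c3)no2)C1` has not been measured in this assay. Its difference from compound 2 is cyclobutyl in place of 4-fluoropiperidin-1-yl on a carbonyl carbon. Going by the values given here, compound 1 carries a different carbonyl substituent and reaches only its limit; compound 3, the one active member, carries a sulfonyl group instead of a carbonyl. Because compound 2 gives > 10000 nM, the step from it to compound 4 cannot be sized from measured values, and the expectation is worded with a wide range. Compound 4 is expected to show a step of an at least 1.4-fold lower number from compound 2 to compound 4 (0.15 log units; that floor lies within the scatter), in the direction of a weaker inhibitor being somewhat less likely than of no change beyond the scatter. The estimate for compound 4 is 7000 nM, with a range from 1500 nM to 30000 nM, and a real chance that only a limit is reported again.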

Compound 4, half-maximal inhibitory concentration: 1500 nM
Compound 4: middle estimate off by 4.7-fold (0.67 log units), on the high side, and the stated range covers the measured number.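

This change shows that a carbonyl compound in the series can give a measured number in this assay: the move to cyclobutyl on the carbonyl carbon gives an at least 6.6-fold lower number from compound 2 to compound 4 (0.82 log units; beyond the scatter). With compound 4 at 1500 nM, the sulfonyl group of compound 3 is no longer the only link shown to go with a number rather than a limit, so this carbonyl substituent is a position where the result depends on the group carried. The step lies beyond the scatter, yet its size is only a floor, because compound 2 holds a limit and not a number: the limit of > 10000 nM in this assay, at which 2 of the 4 values shown sit.

Going by these compounds, what remains open is which part of the change matters, since cyclobutyl differs from 4-fluoropiperidin-1-yl at once in ring size, in the ring nitrogen and in the fluorine. The compounds shown do not tell whether a cyclopropyl, a cyclopentyl or a piperidin-1-yl without fluorine on the same carbonyl carbon would give a number like compound 4 or only a limit like compound 2.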